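Exchanging One Small Aromatic Ring for Another

This account rests on a few compounds, and the source may have more. Where it says the series, first, only, none or still open, it means among the compounds named here.

Compound 1 `Cc1ccc(CN2CCN(c3cccc4[nH]c(-c5ccc(C(C)(C)C)cc5)nc34)CC2)o1`: 705 nM
Compound 2 `Cc1nc(CN2CCN(c3cccc4[nH]c(-c5ccc(C(C)(C)C)cc5)nc34)CC2)c(C)s1`: 21 nM
Compound 3 `CCCCc1nc(CN2CCN(c3cccc4[nH]c(-c5ccc(C(C)(C)C)cc5)nc34)CC2)cn1C`: 26 nM

These three compounds were tested in an assay on isolated protein for displacement of a labelled ligand from Gonadotropin-releasing hormone receptor (Homo sapiens); a lower number here means a stronger inhibitor, a higher number a weaker inhibitor. They share one core and differ only in the group carried on a saturated chain carbon bound to an amine nitrogen in a ring. Compound 2 gives the lowest of the three numbers, and its nearest neighbour is compound 3, the two values lying within the scatter: a 1.2-fold higher number from compound 2 to compound 3 (0.09 log units; within the scatter). The furthest is compound 1, with the 5-methylfuran-2-yl group: a 34-fold lower number from compound 1 to compound 2 (1.53 log units; beyond the scatter), and likewise a 27-fold lower number from compound 1 to compound 3 (1.43 log units; beyond the scatter).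

Compound 4 `CCn1cc(CN2CCN(c3cccc4[nH]c(-c5ccc(C(C)(C)C)cc5)nc34)CC2)nc1C` has not yet been measured. It differs from compound 2 in one place: 1-ethyl-2-methyl-1H-imidazol-4-yl in place of 2,5-dimethyl-1,3-thiazol-4-yl on a saturated chain carbon bound to an amine nitrogen in a ring. Among the measured compounds shown here, the step that bears most directly on this change is the one from compound 2 to compound 3, where a substituted imidazole replaced the thiazole and the number barely moved. Compound 4 carries an imidazole too, with different small alkyl groups, so no step beyond the scatter is expected in this assay. The estimate for compound 4 is therefore 25 nM, with a range from 10 nM to 60 nM, which amounts to an expected step of a 1.2-fold higher number from compound 2 to compound 4 (0.08 log units; within the scatter).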

Compound 4, half-maximal inhibitory concentration: 10 nM
For compound 4 the middle estimate is 2.5-fold (0.40 log units) above the measured one; measured number inside the range.
By their numbers in this assay, from the lowest: compound 4; then compounds 2 and 3 (each within the scatter of the next); then compound 1.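

The step of a 2.1-fold lower number from compound 2 to compound 4 (0.32 log units; beyond the scatter) and the step of a 2.6-fold lower number from compound 3 to compound 4 (0.41 log units; beyond the scatter) are both modest but beyond the scatter, so the 1-ethyl-2-methyl-1H-imidazol-4-yl group is separated from the two groups that could not be told apart before. Compounds 3 and 4 both carry an imidazole, so the ring type alone does not set the number at this position, and the alkyl groups on the ring also count. The gap to the furan also widens, with a 71-fold lower number from compound 1 to compound 4 (1.85 log units; beyond the scatter), although the data shown offer no measured explanation for any of these differences.

Compound 3 and compound 4 differ in two alkyl groups at once, a butyl and a methyl in one against a methyl and an ethyl in the other, so the compounds shown cannot say which of the two accounts for the step. They also leave open how a 2-methyl-1-propyl-1H-imidazol-4-yl group, or a pyridinyl ring, would behave on the same saturated chain carbon bound to an amine nitrogen in a ring.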